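Swapping Iodo for Bromo on a Potent Compound

This account rests on a few compounds, and the source may have more. Where it says the series, first, only, none or still open, it means among the compounds named here.

Measured in a functional assay on A-375 cells (Homo sapiens) for antiproliferative activity, read by CellTiter-Glo, with a stated time of 72 h; on this read-out lower numbers stand for an effect already at smaller amounts and higher numbers for an effect only at larger amounts of compound:
- compound 1 `C[C@H](O)CONC(=O)c1oc2c(F)cncc2c1Nc1ccc(I)cc1F`: 23 nM
- compound 2 `O=C(NOC[C@H](O)CO)c1ccc2cnsc2c1Nc1ccc(I)cc1F`: 10 nM
- compound 3 `O=C(NOCCO)c1ccc2[nH]ncc2c1Nc1ccc(I)cc1F`: 2 nM

Compound 3 stands at the low end of this small set. In this assay compound 3 gives 2 nM, the lowest of the three numbers, and its distance to each of the other two lies beyond the scatter.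

Compound 4 `O=C(NOCCO)c1ccc2[nH]ncc2c1Nc1ccc(Br)cc1F` has not yet been measured. It keeps the structure of compound 3 except for one change, bromo in place of iodo on an aromatic carbon, meta to a fluoro group and para to a large group: bromo in place of iodo on an aromatic carbon.

All three measured compounds carry the 2-fluoro-4-iodophenyl group, so the data hold no direct measure of this swap. The change is a single halogen for another, and only a modest effect is expected. In this assay the expected step is a 2.0-fold higher number from compound 3 to compound 4 (0.30 log units; within the scatter), a small one toward a higher number. For compound 4 the estimated value is 4 nM, with an expected range from 1.5 nM to 12 nM.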

Compound 4, half-maximal effective concentration: 19 nM
Beside the measured number, compound 4's estimate is 4.8-fold (0.68 log units) below it; measured number outside the range, above it.
By their numbers in this assay, from the lowest: compound 3; then compounds 2, 4 and 1 (each within the scatter of the next, the first and the last beyond it).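

In this assay the change from iodo to bromo gives a 9.5-fold higher number from compound 3 to compound 4 (0.98 log units; beyond the scatter), so on the core of compound 3 this position, para to a large group, does not treat the two halogens alike. Going by these compounds alone, this is the only direct reading of the swap, since the earlier compounds all carry the 2-fluoro-4-iodophenyl group and differ from one another in more than one place. Nothing at hand accounts for the size of this step.

From the compounds shown here alone, whether the step carries over to the cores of compound 1 and compound 2 stays open, since it rests on a single pair. Also open, going by these compounds, is where other groups at this position, such as chloro, methyl, ethynyl or a nitrile, would fall relative to iodo and bromo.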